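Hydroxamate series: nitro for benzamido on the benzyl ring

The compounds below may be only part of what the source reports. "The series", "measured", "known", "first", "only" and "open" are said of these compounds alone.

Measured compounds, all in a functional assay on MDA-MB-231 cells (Homo sapiens) for inhibition, read by sulforhodamine B assay; a lower number here means a stronger inhibitor of growth, a higher number a weaker inhibitor of growth:
- compound 1 `CC(=O)Nc1ccc(CN2CCC=C(CCC(=O)NO)C2=O)cc1`: compound 1 gives "not determined" (no result reported)
- compound 2 `COc1ccc(CN2CCC=C(CCC(=O)NO)C2=O)cc1`: compound 2 gives 3860 nM
- compound 3 `O=C(CCC1=CCCN(Cc2ccc(NC(=O)c3ccccc3)cc2)C1=O)NO`: compound 3 gives 6030 nM

Among the compounds with values here, only two numbers are available. Compound 3 gives the higher of the two; the step of a 1.6-fold higher number from compound 2 to compound 3 (0.19 log units; within the scatter) is within the scatter, so compounds 2 and 3 cannot be told apart on these data. Compound 1 adds no number.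

The next compound, compound 4 `O=C(CCC1=CCCN(Cc2ccc([N+](=O)[O-])cc2)C1=O)NO`, is compound 3 with one change: nitro in place of benzamido on an aromatic carbon. Nitro carries no hydrogen-bond donor where benzamido carried one, and sits on the same aromatic carbon, para to a large group.

Within the data shown here, the only measured step that bears on this position is the one from methoxy to benzamido, a 1.6-fold higher number from compound 2 to compound 3 (0.19 log units; within the scatter), and it is within the scatter. Among the measured compounds shown here, no step involving nitro exists, so the direction of the change is unknown; the one precedent at this position argues for a small step in this assay, in either direction.

Compound 4 is therefore expected to fall near compound 3, with the step of a 1.3-fold lower number from compound 3 to compound 4 (0.13 log units; within the scatter) taken as within the scatter. For the measured compounds named here, the estimate for compound 4 is 4500 nM, with a range from 1500 nM to 13000 nM, wide because only the step of a 1.6-fold higher number from compound 2 to compound 3 (0.19 log units; within the scatter) informs it.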

Compound 4, concentration for 50% growth inhibition: 470 nM
Compound 4: the middle estimate sits 9.6-fold (0.98 log units) above what was measured, and the stated range ends above it.
By their numbers in this assay, from the lowest: compound 4; then compounds 2 and 3 (each within the scatter of the next).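

In this assay, the group on this aromatic carbon, para to a large group, clearly can shift the number: nitro gives a 13-fold lower number from compound 3 to compound 4 (1.11 log units; beyond the scatter) and an 8.2-fold lower number from compound 2 to compound 4 (0.91 log units; beyond the scatter), both beyond the scatter, whereas the methoxy and benzamido compounds could not be told apart (a 1.6-fold higher number from compound 2 to compound 3 (0.19 log units; within the scatter)). The position therefore looked flat only across those two groups, and compound 4 now has the lowest number of the three measured compounds, making it the strongest inhibitor of growth among them. Nothing available here accounts for the size of the nitro step, so it stands as an observation without an explanation.

As far as these compounds go, it remains open whether this gain belongs to nitro alone or would also appear with another group on the same carbon, such as nitrile, trifluoromethyl or an amine. Also unsettled is whether the nitro step would carry over to a compound with a longer chain leading to the hydroxamic acid, since all the numbers here come from a single chain length and a single cell line.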